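Compound 1 and a Hydroxylated Side Chain

The source may hold more compounds than are shown below. What is called first, only, known or untested is meant among the compounds shown, and "the series" means these compounds.

Compound 1 `COCCC1=C(N2CC2)C(=O)C(C)=C(N2CC2)C1=O` stands highest of the three numbers in a functional assay on L1210 cells (Mus musculus), with a stated time of 12 days (on this read-out higher numbers stand for higher potency (the scale is a negative logarithm) and lower numbers for lower potency), where compound 1 gives 5.42. Compound 2 `COCCC1=C(N2CC2)C(=O)C(CCOC)=C(N2CC2)C1=O` gives 5.31 in this assay, a result within the scatter of compound 1, while compound 3 `CC1=C(N2CC2)C(=O)C(CCCc2ccccc2)=C(N2CC2)C1=O` gives 4.21, the furthest away. The step from compound 1 to compound 2, a number 0.11 log units lower from compound 1 to compound 2 (within the scatter), shows that this assay barely moves when a chain grows at the methyl. The step from compound 1 to compound 3, a number 1.21 log units lower from compound 1 to compound 3 (beyond the scatter), is the only large one shown and concerns the far end of the chain.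

Compound 4 `COC(CO)C1=C(N2CC2)C(=O)C(C)=C(N2CC2)C1=O` is not yet measured. It differs from compound 1 by 2-hydroxy-1-methoxyethyl in place of 2-methoxyethyl on a double-bonded ring carbon. Among the compounds with values here, no measured step exchanges one oxygen-bearing chain for another, and the only small step in hand, a number 0.11 log units lower from compound 1 to compound 2 (within the scatter), points to little change. Compound 4 is therefore expected to give 5.5 in this assay, between 4.9 and 6.1, a step of a number 0.08 log units higher from compound 1 to compound 4 (within the scatter) that is expected to fall within the scatter.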

Compound 4, logarithm of the reciprocal of the active concentration, log(1/C): 5.75
Compound 4: middle estimate off by 0.25 log units, on the low side; measured number inside the range.
By their numbers in this assay, from the lowest: compound 3; then compounds 2 and 1 (each within the scatter of the next); then compound 4.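

Replacing 2-methoxyethyl with 2-hydroxy-1-methoxyethyl on the double-bonded ring carbon gives a number 0.33 log units higher from compound 1 to compound 4 (beyond the scatter) in this assay, a modest step but the only one shown that goes upward and lies beyond the scatter. The earlier steps shown here left this ring carbon's chain in place or ended lower, whereas this change shows that a chain with one hydrogen-bond donor and two hydrogen-bond acceptors can replace one with no donor and one acceptor here without any loss on this read-out. Nothing available explains the higher number.

The compounds shown do not separate the contribution of the hydroxy from that of the methoxy within the entering chain, as they include no 2-hydroxyethyl chain on this ring carbon. They also leave open how this assay would respond to an amine or a carboxylic acid in place of that hydroxy.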